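The source may hold more compounds than are shown below. What is called first, only, known or untested is meant among the compounds shown, and "the series" means these compounds.

In a functional assay on HEK293 cells for agonist activity at Motilin receptor (Homo sapiens), read by FLIPR (on this read-out lower numbers stand for an effect already at smaller amounts and higher numbers for an effect only at larger amounts of compound), three compounds built on one shared core have been measured. Compound 1 `C[C@@H]1CN(Cc2ccc(-c3ccccc3CN(C)C(=O)COc3ccccc3)cc2)C[C@H](C)N1` gives 79.4 nM. Compound 2 `C[C@@H]1CN(Cc2ccc(-c3ccccc3CN(C)C(=O)CSc3ccccc3)cc2)C[C@H](C)N1` gives 3.16 nM. Compound 3 `Cc1ccc(S(=O)(=O)NCC(=O)N(C)Cc2ccccc2-c2ccc(CN3C[C@@H](C)N[C@@H](C)C3)cc2)cc1` gives 20 nM. Among these three, compound 2 stands lowest: the measured steps run as a 25-fold lower number from compound 1 to compound 2 (1.40 log units; beyond the scatter) and as a 6.3-fold higher number from compound 2 to compound 3 (0.80 log units; beyond the scatter), both beyond the scatter, while the remaining step is a 4.0-fold lower number from compound 1 to compound 3 (0.60 log units; beyond the scatter).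

Compound 4 `Cc1cc(CC(=O)N(C)Cc2ccccc2-c2ccc(CN3C[C@@H](C)N[C@@H](C)C3)cc2)on1` has not yet been measured. It differs from compound 2 by 3-methyl-1,2-oxazol-5-yl in place of phenylsulfanyl on a saturated chain carbon bound to a carbonyl carbon. Among the compounds with values here, two measured steps bear on this change, since each of them also swaps the group on that same saturated chain carbon: a 25-fold lower number from compound 1 to compound 2 (1.40 log units; beyond the scatter) and a 6.3-fold higher number from compound 2 to compound 3 (0.80 log units; beyond the scatter). Both show that a swap at this position moves the number well beyond the scatter, and both alternatives to phenylsulfanyl gave higher numbers than compound 2. Within the data shown here, no measured compound carries a five-membered aromatic ring with two hetero atoms at this position, so the exact size of the coming step is uncertain. For compound 4 a higher number than compound 2 is therefore expected, with the step estimated as a 9.5-fold higher number from compound 2 to compound 4 (0.98 log units; beyond the scatter). Compound 4 is expected to give about 30 nM, within a range from 8 nM to 120 nM.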

Compound 4, half-maximal effective concentration: 1000 nM
Estimate against measurement, compound 4: 33-fold (1.52 log units) below; measured number above the stated range.
By their numbers in this assay, from the lowest: compound 2; then compound 3; then compound 1; then compound 4.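

In this assay, the group on the saturated chain carbon bound to a carbonyl carbon turns out to have a far wider reach than the first three compounds suggested: 3-methyl-1,2-oxazol-5-yl gives a 320-fold higher number from compound 2 to compound 4 (2.50 log units; beyond the scatter) and a 50-fold higher number from compound 3 to compound 4 (1.70 log units; beyond the scatter) and also a 13-fold higher number from compound 1 to compound 4 (1.10 log units; beyond the scatter), so even phenoxy, the poorest of the earlier groups, stands well ahead of it. Phenoxy, phenylsulfanyl and ((4-methylphenyl)sulfonyl)amino all join a six-membered aromatic ring of carbon only to the chain carbon through an oxygen, sulfur or nitrogen atom, while compound 4 sets a five-membered aromatic ring with 2 hetero atoms on that carbon with no such linking atom, so two features change together in this step. Nothing available gives a measured reason for a rise of this size.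

Which of those two features goes with the rise stays open: a phenyl group on that chain carbon, or 3-methyl-1,2-oxazol-5-yl joined through a sulfur atom, would separate them. From the compounds shown here alone, how a carboxylic acid or a plain amine at this place would read in this assay also stays open.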